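This account rests on a few compounds, and the source may have more. Where it says the series, first, only, none or still open, it means among the compounds named here.

The measured compounds:
Compound 1, `Cn1c(COc2cccc(C(=O)O)c2)nc2ccc(Oc3ccc(F)cc3)nc21`, in an ADME assay for permeability, using PAMPA, with a stated time of 4 h (a higher number here means that the compound crosses the layer faster, a lower number that the compound crosses the layer more slowly), gives 8.6 10^-6 cm/s.
Compound 2, `Cc1ccc(Oc2ccc3nc(COc4cccc(C(=O)O)c4)n(C)c3n2)cc1F`, gives 14.8 10^-6 cm/s.
Compound 3, `Cn1c(COc2cccc(C(=O)O)c2)nc2ccc(Oc3cc(Cl)ccn3)cc21`, gives 10.3 10^-6 cm/s.

Compound 3 stands second highest of the three numbers, but its gap to compound 1 and its gap to compound 2 both lie within the scatter, so no order among them can be read. Compound 4, `Cc1cc(Cl)cnc1Oc1ccc2nc(COc3cccc(C(=O)O)c3)n(C)c2c1`, differs from compound 3 in one place: 5-chloro-3-methylpyridin-2-yl in place of 4-chloropyridin-2-yl on an oxygen on an aromatic ring. One measured step resembles this change, 3-fluoro-4-methylphenyl in place of 4-fluorophenyl on an oxygen on an aromatic ring, which gave a 1.7-fold higher number from compound 1 to compound 2 (0.24 log units; within the scatter). On that basis the step to compound 4 is expected to be a 1.2-fold higher number from compound 3 to compound 4 (0.07 log units; within the scatter), nothing beyond the scatter. Compound 4 is therefore estimated at 12 10^-6 cm/s, with a range from 7 10^-6 cm/s to 20 10^-6 cm/s.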

Compound 4, apparent permeability: 13.7 10^-6 cm/s
Compound 4: middle estimate off by 1.1-fold (0.06 log units), on the low side, and the stated range covers the measured number.
By their numbers in this assay, from the lowest: compounds 1, 3, 4 and 2 (each within the scatter of the next).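

Read in this assay, the exchange of 4-chloropyridin-2-yl for 5-chloro-3-methylpyridin-2-yl gives a 1.3-fold higher number from compound 3 to compound 4 (0.12 log units; within the scatter) and so shows no readable effect. The earlier step at this place joined two phenyl groups, whereas this one shows that a chloropyridinyl group with an added methyl also leaves the number within the scatter. Nothing at hand bears on the reason for this result. The compounds shown leave open whether an aliphatic amine or a longer alkyl chain in place of the aromatic ring on this oxygen would give a step beyond the scatter.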